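The source may report more compounds than this note shows. Statements on the series, on what has been measured and on what is new or still open speak of the compounds shown alone.

Measured in a functional assay on A549 cells (Homo sapiens) for inhibition, read by colorimetric assay and MTT assay, with a stated time of 72 h; a higher number here means a weaker inhibitor, a lower number a stronger inhibitor:
compound 1 `COc1cc(C(=O)NNC(=S)Nc2csc(-c3ccccc3)c2)cc(OC)c1OC` gives 39000 nM
compound 2 `COc1ccc(C(=O)NNC(=S)Nc2csc(-c3ccccc3)c2)cc1` gives 36000 nM
compound 3 `O=C(NNC(=S)Nc1csc(-c2ccccc2)c1)c1ccc(O)cc1` gives 75000 nM

Compound 2 has the lowest of the three numbers in this assay. Its nearest neighbour is compound 1, whose value lies within the scatter of that of compound 2, so the two cannot be ordered. Compound 3 stands furthest away: a 2.1-fold higher number from compound 2 to compound 3 (0.32 log units; beyond the scatter), a modest step that lies beyond the scatter.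

Compound 4 `COc1ccc(C(=O)NNC(=S)Nc2csc(-c3ccccc3)c2)cc1OC` has not been measured. It differs from compound 2 in one place: methoxy in place of hydrogen on an aromatic carbon. Among the compounds with values here, none of the measured steps makes the same change. The step from compound 2 to compound 3 alters the oxygen-bound group and is of modest size. Compounds 1 and 2, which differ only in the groups on that ring, show values within the scatter of each other, which suggests that one more methoxy on this ring need not move the number far. Compound 4 is therefore expected to sit close to compound 2, with a 1.0-fold higher number from compound 2 to compound 4 (0.01 log units; within the scatter) as the expected step, not beyond the scatter. The estimate for compound 4 in this assay is 37000 nM, with a range from 20000 nM to 70000 nM.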

Compound 4, half-maximal inhibitory concentration: 20000 nM
Compound 4: middle estimate off by 1.9-fold (0.27 log units), on the high side; low and high end bracket the measured number.
By their numbers in this assay, from the lowest: compounds 4, 2, 1 and 3 (each within the scatter of the next, the first and the last beyond it).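

In this assay, the change of methoxy in place of hydrogen on this aromatic carbon, ortho to a methoxy group and meta to a large group, gives a 1.8-fold lower number from compound 2 to compound 4 (0.26 log units; within the scatter) and so does not separate compound 4 from compound 2. The other single change around compound 4, hydrogen in place of methoxy on an aromatic carbon, gives a 2.0-fold lower number from compound 1 to compound 4 (0.29 log units; within the scatter), so compounds 1, 2 and 4, which the earlier values could not link through single changes alone, now form a connected series with no step beyond the scatter.

The compounds shown leave open what a different group on this carbon would do, such as an amine, a carboxylic acid or a longer chain like butoxy. They carry only hydrogen or methoxy there, so the series cannot say whether this place tolerates other groups as well.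

No measurement offers an explanation for these values.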